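The source may report more compounds than this note shows. Statements on the series, on what has been measured and on what is new or still open speak of the compounds shown alone.

Measured compounds:
compound 1 `COc1ccc(N(C(=O)CN2C=CN(c3ccccc3)C(=O)[C@@H](Cc3n[nH]c4ccccc34)C2=O)C(C)C)cc1` — in a functional assay on CHO cells for agonist activity at Melanocyte-stimulating hormone receptor (Homo sapiens), read by a luciferase reporter, with a stated time of 4 h (on this read-out higher numbers stand for an effect only at larger amounts of compound and lower numbers for an effect already at smaller amounts), compound 1 gives 1550 nM
compound 2 `COc1ccc(N(C(=O)CN2C=CN(c3ccccc3)C(=O)C(Cc3n[nH]c4ccccc34)C2=O)C(C)C)cc1` — compound 2 gives 29.5 nM
compound 3 `COc1ccc(N(C(=O)CN2C=CN(c3cccnc3)C(=O)C(Cc3n[nH]c4ccccc34)C2=O)C(C)C)cc1` — compound 3 gives 178 nM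

Compound 2 stands at the lowest number of the three. Its nearest neighbour is compound 3, and compound 1 is furthest away. The step of a 53-fold lower number from compound 1 to compound 2 (1.72 log units; beyond the scatter) is large, and the two compounds are distinguished only by the fact that one of compounds 1 and 2 is drawn with a defined configuration and the other without, at the place where they differ. The step of a 6.0-fold higher number from compound 2 to compound 3 (0.78 log units; beyond the scatter) is modest.

Compound 4 `O=C1C(Cc2n[nH]c3ccccc23)C(=O)N(c2ccccc2)C=CN1CC(=O)N1CCCCc2ccccc21` differs from compound 2 in a different region: a group of 11 heavy atoms (10 carbon, 1 nitrogen; one six-membered aromatic ring of carbon only, one seven-membered non-aromatic ring with 1 hetero atom) in place of a group of 12 heavy atoms (10 carbon, 1 nitrogen, 1 oxygen; one six-membered aromatic ring of carbon only), on a carbonyl carbon. Neither measured step touches this carbonyl substituent; one concerns the drawn configuration at the saturated ring carbon, the other the aromatic ring on the amide-type nitrogen in the ring. Within the data shown here, there is therefore no direct precedent for this change, and the expectation rests on the general size of steps seen so far, with the replacement of one amide substituent by another of similar size most plausibly costing a modest amount. The step of a 3.7-fold higher number from compound 2 to compound 4 (0.57 log units; beyond the scatter) is expected. Compound 4 is estimated at 110 nM in this assay, with a range from 20 nM to 600 nM.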

Compound 4, half-maximal effective concentration: 1.59 nM
Estimate against measurement, compound 4: 69-fold (1.84 log units) above; the measured number lies below the stated range.
By their numbers in this assay, from the lowest: compound 4; then compound 2; then compound 3; then compound 1.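

Until now the carbonyl substituent had stayed the same, and in this assay this position proves highly responsive: exchanging isopropyl(4-methoxyphenyl)amino for the group with a seven-membered non-aromatic ring with 1 hetero atom gives a 19-fold lower number from compound 2 to compound 4 (1.27 log units; beyond the scatter). This is the first change shown that takes the number below that of compound 2, and it does so with the oxygen and the hydrogen-bond acceptor of the leaving group gone, so neither is needed for a low number in this series. What lies behind the step is not explained by anything measured here, as the available evidence concerns only the drawn configuration in another part of the molecule.

The exchange alters several features at once, so the compounds shown do not separate the contribution of the seven-membered ring from that of losing the isopropyl or the methoxy group, and a six-membered ring in its place, or a methoxy group on the entering aromatic ring, would bear on this. From the compounds shown here alone, it also remains open whether the same step holds alongside pyridin-3-yl on the amide-type nitrogen in the ring, or with a drawn S configuration at the saturated ring carbon.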